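Benzothiazolyl urea series: substituting the indole nitrogen

This account rests on a few compounds, and the source may have more. Where it says the series, first, only, none or still open, it means among the compounds named here.

Compound 2 `CCN(CC)Cc1ccc2nc(NC(=O)N/N=C/c3c[nH]c4ccccc34)sc2c1` gives 3300 nM in a functional assay on A549 cells (Homo sapiens) for cytotoxicity, read by MTT assay, with a stated time of 72 h (on this read-out lower numbers stand for stronger inhibition and higher numbers for weaker inhibition), the highest of the three numbers, yet within the scatter of compound 3 `CC1CCN(Cc2ccc3nc(NC(=O)N/N=C4\C(=O)Nc5ccc(F)cc54)sc3c2)CC1` at 3010 nM and of compound 1 `CN(C)Cc1ccc2nc(NC(=O)N/N=C3\C(=O)Nc4ccc(F)cc43)sc2c1` at 2310 nM. Among the compounds with values here, the only single-site step measured, a 1.3-fold higher number from compound 1 to compound 3 (0.11 log units; within the scatter), concerns the amine on the chain and stays within the scatter. Compound 4 `CCN(CC)Cc1ccc2nc(NC(=O)N/N=C/c3cn(Cc4ccc(Cl)cc4Cl)c4ccccc34)sc2c1` differs from compound 2 by 2,4-dichlorobenzyl in place of hydrogen on an aromatic nitrogen. Within the data shown here, no measured step touches the aromatic nitrogen, so nothing points to a change beyond the scatter in this assay; the uncertainty is simply wider. Compound 4 is therefore expected at about 3000 nM, between 1000 nM and 9000 nM. The step expected is a 1.1-fold lower number from compound 2 to compound 4 (0.04 log units; within the scatter), none beyond the scatter.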

Compound 4, half-maximal inhibitory concentration: 1900 nM
Compound 4: middle estimate off by 1.6-fold (0.20 log units), on the high side; the measured number falls inside the stated range.
By their numbers in this assay, from the lowest: compounds 4, 1, 3 and 2 (each within the scatter of the next).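

Within the data shown here, the first measured step on this aromatic nitrogen, in this assay, is a 1.7-fold lower number from compound 2 to compound 4 (0.24 log units; within the scatter). Among these compounds, the hydrogen there can therefore give way to a group as large as 2,4-dichlorobenzyl without a step beyond the scatter, which the earlier compounds, varied only at the amine on the chain, could not show. No evidence on the reason for this result is available.

On these data alone, whether a plain methyl, an unsubstituted benzyl or a chain ending in a carboxylic acid on this nitrogen would also stay within the scatter remains open. A single group cannot show whether substitution here matters at all.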